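Swapping the amide cap for a chloropyrimidine ring

The source may report more compounds than this note shows. Statements on the series, on what has been measured and on what is new or still open speak of the compounds shown alone.

Compound 1 `Cc1nc(S(C)(=O)=O)ccc1Oc1ncnc(OC2CCN(C(=O)OC(C)C)CC2)c1F` gives 21 nM in a functional assay on isolated protein for inhibition of Glucose-dependent insulinotropic receptor (Homo sapiens), read by HTRF and cAMP accumulation; on this read-out lower numbers stand for an effect already at smaller amounts and higher numbers for an effect only at larger amounts of compound.
Compound 2 `Cc1nc(S(C)(=O)=O)ccc1Oc1ncnc(OC2CCN(C(=O)C3(F)CCC3)CC2)c1F` gives 24.7 nM in this assay.

Among the two measured compounds, compound 2 has the higher number, yet its distance to compound 1 is within the scatter, so the two cannot be told apart. Going by the values given here, the only measured step, a 1.2-fold higher number from compound 1 to compound 2 (0.07 log units; within the scatter), exchanged one cap on the carbonyl carbon for another and left the number essentially where it was.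

Compound 3 `Cc1nc(S(C)(=O)=O)ccc1Oc1ncnc(OC2CCN(C(=O)c3ncc(Cl)cn3)CC2)c1F` carries a third cap at the same place: a group of 7 heavy atoms (4 carbon, 2 nitrogen, 1 chlorine; one six-membered aromatic ring with 2 hetero atoms) in place of a group of 5 heavy atoms (4 carbon, 1 fluorine; one four-membered non-aromatic ring of carbon only), on a carbonyl carbon. The measured step bears on this change only loosely. Among the compounds with values here, it shows that the carbonyl cap tolerated one exchange without a shift beyond the scatter, but neither measured compound carries an aromatic ring there, so there is no direct precedent for the entering group.

On that basis the expectation for compound 3 is a number close to those of compound 1 and compound 2, with a wide range to reflect the missing precedent. For compound 3 the estimate in this assay is 25 nM, with a range from 8 nM to 80 nM. This corresponds to an expected step of a 1.0-fold higher number from compound 2 to compound 3 (0.01 log units; within the scatter), which means no change beyond the scatter is anticipated.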

Compound 3, half-maximal effective concentration: 6.12 nM
Compound 3: the middle estimate sits 4.1-fold (0.61 log units) above what was measured; measured number below the stated range.
By their numbers in this assay, from the lowest: compound 3; then compounds 1 and 2 (each within the scatter of the next).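

The earlier exchange at this carbonyl carbon, whose other neighbour is the amide-type nitrogen in a ring, stayed within the scatter, but the 5-chloropyrimidin-2-yl group gives a change that can be read: in this assay there is a 4.0-fold lower number from compound 2 to compound 3 (0.61 log units; beyond the scatter), and also a 3.4-fold lower number from compound 1 to compound 3 (0.54 log units; beyond the scatter). The position is therefore not indifferent to what it carries, and among these three compounds, a lower number here means an effect already at smaller amounts, with the aromatic cap of compound 3 the only one to stand apart from the others, though the step is modest in size. No measurement shown here gives an explanation for this step.

The entering group differs from both earlier caps in its aromatic ring, its two ring nitrogens and its chlorine all at once, so the compounds shown cannot say which of these parts goes with the lower number. As far as these compounds go, how a phenyl ring, a 4-chlorophenyl ring or a pyrimidin-2-yl ring without chlorine would read at this carbonyl carbon remains open.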